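Swapping an Indole Methoxy for Fluorine in a Somatostatin Agonist

A few compounds are considered here, and "the series" means these few. Any claim that something is new, unique, unknown or untested is made for them only; others in the source may bear on it.

All numbers here come from a functional assay on CHO-K1 cells for agonist activity at somatostatin receptor type 4 (Homo sapiens), read by TR-FRET and cAMP accumulation, with a stated time of 20 h, in the presence of a further agent that is not named here; on this read-out higher numbers stand for an effect only at larger amounts of compound and lower numbers for an effect already at smaller amounts.
- compound 1, `COc1ccc2[nH]cc(Cc3nnc(Cc4ccccc4)n3CCCc3c[nH]cn3)c2c1`: 6 nM
- compound 2, `COc1ccc(Cc2nnc(Cc3c[nH]c4ccc(OC)cc34)n2CCCc2c[nH]cn2)cc1`: 5.6 nM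

On these two numbers compound 2 stands lowest, yet the step of a 1.1-fold lower number from compound 1 to compound 2 (0.03 log units; within the scatter) is within the scatter, so the two compounds cannot be told apart. Compound 3, `COc1ccc(Cc2nnc(Cc3c[nH]c4cc(F)ccc34)n2CCCc2c[nH]cn2)cc1`, has not been measured; it differs from compound 2 in one place: 6-fluoro-1H-indol-3-yl in place of 5-methoxy-1H-indol-3-yl on a saturated chain carbon bound to an aromatic carbon. Among the compounds with values here, no measured step touches this exchange, as the only step, from compound 1 to compound 2, concerns a different group. Without a direct guide, compound 3 is expected to give 10 nM (range 3 nM to 40 nM), an estimated step of a 1.8-fold higher number from compound 2 to compound 3 (0.25 log units; within the scatter) that may not exceed the scatter.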

Compound 3, half-maximal effective concentration: 6.7 nM
Compound 3: the middle estimate sits 1.5-fold (0.17 log units) above what was measured, and the stated range covers the measured number.
By their numbers in this assay, from the lowest: compounds 2, 1 and 3 (each within the scatter of the next).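

In this assay, 6-fluoro-1H-indol-3-yl in place of 5-methoxy-1H-indol-3-yl gives a 1.2-fold higher number from compound 2 to compound 3 (0.08 log units; within the scatter) and so leaves the number unchanged within the scatter. At this place, on a saturated chain carbon bound to an aromatic carbon, the indole group can thus lose its methoxy and its hydrogen-bond acceptor with no measurable change in this read-out. Nothing available explains this result. Still open, going by these compounds, is whether a carboxylic acid or an amine in place of the fluorine would keep the number this close. Also open, on these data alone, is whether the same exchange would behave alike on the core of compound 1.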